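The compounds below may be only part of what the source reports. "The series", "measured", "known", "first", "only" and "open" are said of these compounds alone.

Compound 1 `CS(=O)(=O)c1ccc(Nc2ncc(F)c(Nc3nc4ccccc4s3)n2)cc1` is the starting point: in a functional assay on PC-3 cells (Homo sapiens) for antiproliferative activity, read by MTT assay, with a stated time of 48 h (on this read-out lower numbers stand for stronger inhibition and higher numbers for weaker inhibition), compound 1 gives 2830 nM. Compound 2 `CS(=O)(=O)c1ccc(Nc2ncc(F)c(Nc3nc4ccc(F)cc4s3)n2)cc1` carries a fluoro in place of hydrogen on an aromatic carbon. In this assay compound 2 reaches only the limit of the assay, > 50000 nM, so no number exists for it. The change from the parent amounts to an at least 17-fold higher number from compound 1 to compound 2 (1.24 log units; beyond the scatter). For compound 2 there is thus only a limit of > 50000 nM in this assay, at which 1 of the 2 values shown sits, and no measured value against which the next step can be set.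

Compound 3 `COc1ccc2nc(Nc3nc(Nc4ccc(S(C)(=O)=O)cc4)ncc3F)sc2c1` has not yet been measured. It differs from compound 2 by methoxy in place of fluoro on an aromatic carbon. Going by the values given here, the only measured step that touches this position is an at least 17-fold higher number from compound 1 to compound 2 (1.24 log units; beyond the scatter), which shows a large loss when a fluoro was introduced there. Whether a methoxy at the same place behaves like that fluoro or like the hydrogen of compound 1 cannot be read from two compounds. Compound 3 is therefore expected to fall between the two at about 20000 nM, within 3000 nM to 50000 nM. That estimate implies an expected step of an at least 2.5-fold lower number from compound 2 to compound 3 (0.39 log units; beyond the scatter), its size uncertain since it starts from a limit.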

Compound 3, half-maximal inhibitory concentration: 1270 nM
Beside the measured number, compound 3's estimate is 16-fold (1.20 log units) above it; the whole stated range lies above it.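

In this assay, the place on the six-membered aromatic ring turns out to respond in both directions, which the fluoro alone could not show. Methoxy in place of fluoro gives an at least 39-fold lower number from compound 2 to compound 3 (1.59 log units; beyond the scatter), and methoxy in place of hydrogen gives a 2.2-fold lower number from compound 1 to compound 3 (0.35 log units; beyond the scatter), so the second step is modest but still beyond the scatter. A substituent at this place therefore does not by itself cost activity: among these three compounds the loss is confined to the fluoro of compound 2, while the methoxy of compound 3 gives the lowest number of the series.

Whether the gain is specific to methoxy remains open, as the compounds shown do not tell how a chloro, an ethoxy, a longer alkoxy chain or an amine at the same place would behave, or whether the order of the three would hold on another cell line. The true size of the step away from the fluoro also stays unknown, since compound 2 has only a limit and no number: the limit of > 50000 nM in this assay, at which 1 of the 3 values shown sits.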